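The compounds below may be only part of what the source reports. "The series", "measured", "known", "first", "only" and "open" are said of these compounds alone.

Compound 1 `COc1cc(C(=O)c2sc3ccccc3c2-c2ccccc2)cc(OC)c1OC` carries a phenyl group on its core and in a functional assay on Jurkat cells (Homo sapiens) for antiproliferative activity, read by MTT assay, with a stated time of 72 h (on this read-out higher numbers stand for weaker inhibition and lower numbers for stronger inhibition), gives 1500 nM. Among the measured compounds shown here, on the numbers so far, compound 1 stands lowest of the two measured compounds; its nearest neighbour is compound 2 `COc1cc(C(=O)c2sc3ccccc3c2-c2ccc(C)cc2)cc(OC)c1OC`, which in this assay gives 3300 nM. For the measured compounds named here, the only measured step, a 2.2-fold higher number from compound 1 to compound 2 (0.34 log units; beyond the scatter), shows a modest weakening from a small addition on an aromatic carbon of the phenyl group. Compound 3 `CCOc1ccc(Nc2c(C(=O)c3cc(OC)c(OC)c(OC)c3)sc3ccccc23)cc1` is not yet measured; it differs from compound 1 by (4-ethoxyphenyl)amino in place of phenyl on an aromatic carbon. Going by the values given here, no measured step bears directly on this change, which is larger than the one from compound 1 to compound 2, so the expectation rests loosely on compound 1 at 1500 nM and on the weakening seen in a 2.2-fold higher number from compound 1 to compound 2 (0.34 log units; beyond the scatter). A moderate increase in the number, with wide uncertainty, is expected for compound 3 in this assay, giving an estimated 1.7-fold higher number from compound 1 to compound 3 (0.22 log units; within the scatter). For compound 3 the expected value is 2500 nM, in a range from 700 nM to 9000 nM.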

Compound 3, half-maximal inhibitory concentration: 300 nM
Compound 3: the middle estimate sits 8.3-fold (0.92 log units) above what was measured, and the stated range ends above it.
By their numbers in this assay, from the lowest: compound 3; then compound 1; then compound 2.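

Set against the small methyl addition, which raised the number, the change at this aromatic carbon of the five-membered ring runs the other way: (4-ethoxyphenyl)amino in place of phenyl gives a 5.0-fold lower number from compound 1 to compound 3 (0.70 log units; beyond the scatter) in this assay. The same group in place of 4-methylphenyl gives an 11-fold lower number from compound 2 to compound 3 (1.04 log units; beyond the scatter), so this position accepts a larger group carrying an amino nitrogen and an ethoxy oxygen, and that group gives the lowest number of the three. Nothing at hand explains this shift.

The amino nitrogen and the ethoxy group enter together, so the compounds shown leave open which of them goes with the lower number. An unsubstituted phenylamino group would separate the two, and methoxy or a longer alkoxy chain in place of ethoxy would test how much that end of the group matters.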